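The source may hold more compounds than are shown below. What is called first, only, known or untested is meant among the compounds shown, and "the series" means these compounds.

Working notes on the series. Compound 1 `COc1ccc(CN2CCC(NC(=O)COc3ccc4c(=O)c(-c5ccccc5)coc4c3)CC2)cc1` in a functional assay on HepG2 cells (Homo sapiens) for cytotoxicity, read by MTT assay, with a stated time of 72 h (on this read-out lower numbers stand for stronger inhibition and higher numbers for weaker inhibition), gives > 20000 nM, which is a limit of the assay rather than a number (the limit of > 20000 nM in this assay, at which 1 of the 2 values shown sits). Compound 2 `O=C(COc1ccc(-c2cc(=O)c3ccccc3o2)cc1)NC1CCN(Cc2ccccc2)CC1` in this assay gives 15500 nM, the only number shown so far in the series. Compound 3 `O=C(COc1ccc(-c2cc(=O)c3ccccc3o2)cc1)NC1CCN(C(=O)c2ccccc2)CC1` is not yet measured; it differs from compound 2 by benzoyl in place of benzyl on an amine nitrogen in a ring. For the measured compounds named here, no measured step of this kind exists here, so the expected change in this assay is none beyond the scatter, or at most a small weakening. Compound 3 is therefore estimated at 20000 nM, expected between 8000 nM and 50000 nM. This estimate means an expected step of a 1.3-fold higher number from compound 2 to compound 3 (0.11 log units; within the scatter).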

Compound 3, half-maximal inhibitory concentration: > 20000 nM
Compound 3: only a limit was reported (the forecaster's own chance of this, stated with the estimate: 45%); the middle value sits exactly at the limit.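

For compound 3 the value in this assay is a limit of the assay, not a number. Benzoyl in place of benzyl on the amine nitrogen in the ring therefore gives only a floor, an at least 1.2-fold higher number from compound 2 to compound 3 (0.11 log units; that floor lies within the scatter), and the true size of the step stays unknown; no lower number appears with this change. Most of the series now rests on that limit: the limit of > 20000 nM in this assay, at which 2 of the 3 values shown sit.

The compounds shown leave open how an acetyl group or a longer chain such as phenethyl would read on this nitrogen. As far as these compounds go, whether benzoyl gives a similar result on the core of compound 1 also stays open.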